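This account rests on a few compounds, and the source may have more. Where it says the series, first, only, none or still open, it means among the compounds named here.

Measured so far:
compound 1 `CN1Cc2ccccc2[C@](O)(c2ccccc2)C1`: 6.23
compound 2 `CN1Cc2ccccc2[C@@](O)(c2ccccc2)C1`: 6.23

Both were tested in a functional assay (muscle tissue) for positive allosteric modulation, with Rattus norvegicus as the target; a higher number here means a more potent compound, by a factor of ten per unit of this negative logarithm, a lower number a less potent compound. Compound 2 stands level with compound 1 at the digits shown, and the step of no change at the digits printed from compound 1 to compound 2 (within the scatter) lies within the scatter of this assay. The only thing separating them is the fact that compounds 1 and 2 differ only in the configuration as drawn, a single stereocentre at a saturated ring carbon.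

Compound 3 `CN1Cc2ccccc2C(O)(c2ccccc2)C1` has not yet been measured. Its change from compound 2 is the two compounds have the same atoms and bonds; at least one stereo element is drawn with a configuration in one of them and without one in the other: 1 of 1 stereo elements differ; a stereocentre at a saturated ring carbon is drawn S in compound 2 and without a configuration in compound 3. Compound 3 therefore spans the two configurations that compound 1 and compound 2 carry separately. Within the data shown here, the one measured step that bears on this, no change at the digits printed from compound 1 to compound 2 (within the scatter), showed no change beyond the scatter between the two drawn configurations, so for compound 3 no step beyond the scatter is expected: no change at the digits printed from compound 2 to compound 3 (within the scatter). Compound 3 is estimated at 6.23, with a range from 5.9 to 6.5.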

Compound 3, negative logarithm of the half-maximal effective concentration: 6.25
Estimate against measurement, compound 3: 0.02 log units below, and the stated range covers the measured number.
By their numbers in this assay, from the lowest: compounds 1, 2 and 3 (each within the scatter of the next).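

In this assay, the form drawn without a configuration at the saturated ring carbon reads the same as either drawn form: a number 0.02 log units higher from compound 2 to compound 3 (within the scatter) and a number 0.02 log units higher from compound 1 to compound 3 (within the scatter) both lie within the scatter. Compound 1 and compound 2 had compared only the two drawn configurations, whereas compound 3 adds a third way of drawing this stereocentre. All three readings at this position therefore agree within the scatter, and no change in how the stereocentre is drawn separates these compounds in this assay.

All three compounds carry the same atoms and bonds, so the stereocentre is the only feature varied and the shared core stays untouched. Among these compounds, what an amine, a carboxylic acid or a longer chain on that core would do remains open, as does whether the configuration would still make no difference in such compounds.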